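The source may report more compounds than this note shows. Statements on the series, on what has been measured and on what is new or still open speak of the compounds shown alone.

Measured in an assay on isolated protein for inhibition of matrix metalloproteinase-9 (Homo sapiens); a higher number here means a weaker inhibitor, a lower number a stronger inhibitor:
compound 1 `Cc1ccc(Oc2ccc(N(CC(=O)NO)S(C)(=O)=O)cc2)cc1`, 31 nM
compound 2 `CCCS(=O)(=O)N(C[C@H](O)C(=O)NO)c1ccc(Oc2ccc(C)cc2)cc1`, 124 nM
compound 3 `Cc1ccc(Oc2ccc(N(C[C@H](O)C(=O)NO)S(=O)(=O)C(C)C)cc2)cc1`, 286 nM

Compound 3 holds the highest of the three numbers. Within the data shown here, the nearest number is separated from it by a 2.3-fold higher number from compound 2 to compound 3 (0.36 log units; beyond the scatter); compound 1 lies further off, but differs in more than one place, so no single step is drawn to it. Compound 4 `Cc1ccc(Oc2ccc(N(C[C@H](O)C(=O)NO)S(=O)(=O)c3ccccc3)cc2)cc1` differs from compound 3 by phenyl in place of isopropyl on a sulfonyl sulfur. Among the measured compounds shown here, the only measured step at the sulfonyl sulfur is a 2.3-fold higher number from compound 2 to compound 3 (0.36 log units; beyond the scatter), a modest rise for a branched chain in place of a straight one; nothing measured covers a ring entering at that position. The expectation for compound 4 in this assay is therefore a step of a 1.4-fold lower number from compound 3 to compound 4 (0.16 log units; within the scatter), close to the scatter, with the direction uncertain. Compound 4 is estimated at 200 nM, between 60 nM and 700 nM.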

Compound 4, half-maximal inhibitory concentration: 344 nM
The estimate for compound 4 lay 1.7-fold (0.24 log units) below the measured number, and the stated range covers the measured number.
By their numbers in this assay, from the lowest: compound 1; then compound 2; then compounds 3 and 4 (each within the scatter of the next).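

In this assay phenyl in place of isopropyl on a sulfonyl sulfur gives a 1.2-fold higher number from compound 3 to compound 4 (0.08 log units; within the scatter) and so a ring can stand at this position with no change beyond the scatter. Phenyl in place of propyl gives a 2.8-fold higher number from compound 2 to compound 4 (0.44 log units; beyond the scatter) and so propyl keeps a lower number than either isopropyl or phenyl. No evidence here accounts for these steps.

From the compounds shown here alone, whether a substituted phenyl, a benzyl or a chain longer than propyl on the sulfonyl sulfur would shift the number remains open. Compound 1 carries methyl there but differs in more than one place, so the effect of methyl cannot be read separately.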